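From Compound 2 to Compound 4: Losing the Anilino Group

A few compounds are considered here, and "the series" means these few. Any claim that something is new, unique, unknown or untested is made for them only; others in the source may bear on it.

Measured in a functional assay (strain AB) with Danio rerio as the target, read by microscopy, with a stated time of 1 h; a higher number here means that more compound is needed for the effect, a lower number that less compound is needed:
Compound 1 `CCC1CCc2c(sc(NC(=O)Nc3ccc(Cl)cc3)c2C(N)=O)C1`: > 25000 nM (a limit)
Compound 2 `CCN1CCc2c(sc(NC(=O)Nc3ccccc3)c2C(N)=O)C1`: > 25000 nM (a limit)
Compound 3 `CCN1CCc2c(sc(NC(=O)Nc3cccc(Cl)c3Cl)c2C(N)=O)C1`: 17400 nM

Compound 2 gives no exact number, only the limit > 25000 nM. The set crowds at one edge: the limit of > 25000 nM in this assay, at which 2 of the 3 values shown sit. In compound 4 `CCN1CCc2c(sc(NC=O)c2C(N)=O)C1`, hydrogen stands in place of anilino on a carbonyl carbon: hydrogen in place of anilino on a carbonyl carbon. For the measured compounds named here, the one measured step that bears on this, an at least 1.4-fold lower number from compound 2 to compound 3 (0.15 log units; that floor lies within the scatter), alters that anilino group instead of removing it, and its floor lies within the scatter. No step beyond the scatter towards a lower number is therefore expected in this assay, and another limit is the likely outcome. Compound 4 is estimated at 30000 nM, with an expected range of 15000 nM to 60000 nM. This estimate means an expected step that the limit leaves unreadable from compound 2 to compound 4.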

Compound 4, half-maximal effective concentration: > 25000 nM
Compound 4: a limit, no number (the forecaster's own chance of this, stated with the estimate: 85%); the middle value is on the limit's open side.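

For the compounds shown here, compound 2 and compound 4 each give only a limit in this assay, so no step between them can be read. The compounds shown leave open whether hydrogen in place of anilino on a carbonyl carbon changes the number in this assay at all.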